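This account rests on a few compounds, and the source may have more. Where it says the series, first, only, none or still open, it means among the compounds named here.

In a functional assay on A549 cells (Homo sapiens) for antiproliferative activity, read by MTT assay, with a stated time of 72 h (a higher number here means a weaker inhibitor, a lower number a stronger inhibitor), compound 1 `COc1ccc(-c2sc(N(C)C)nc2-c2cc(OC)c(OC)c(OC)c2)cc1` gives > 10000 nM as its reading, which is a limit and not a number. Compound 2 `COc1cc(-c2nc(C)sc2-c2ccc(C)cc2)cc(OC)c1OC` gives 1950 nM as a measured value. Compound 3 `COc1cc(-c2nc(C)sc2-c2ccc(C(F)(F)F)cc2)cc(OC)c1OC` gives 4290 nM and so holds the higher of the two numbers, with compound 2 as its nearest neighbour. Compound 4 `COc1ccc(-c2sc(C)nc2-c2cc(OC)c(OC)c(OC)c2)cc1` differs from compound 3 by methoxy in place of trifluoromethyl on an aromatic carbon. Within the data shown here, one measured step bears on this change, at the same aromatic carbon: a 2.2-fold higher number from compound 2 to compound 3 (0.34 log units; beyond the scatter) and that step is modest. Among the measured compounds shown here, compound 1 also carries methoxy but differs elsewhere as well, so it sets no size for the step. Going by compound 3 and the step of a 2.2-fold higher number from compound 2 to compound 3 (0.34 log units; beyond the scatter) with trifluoromethyl on the side of the higher number, a lower number of similar or somewhat larger size is expected in this assay for this change. The expected change is a 3.6-fold lower number from compound 3 to compound 4 (0.55 log units; beyond the scatter) as an estimate with wide uncertainty. For compound 4 the estimated value is 1200 nM with an expected range of 150 nM to 5000 nM in all.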

Compound 4, half-maximal inhibitory concentration: 2560 nM
Compound 4: middle estimate off by 2.1-fold (0.33 log units), on the low side; low and high end bracket the measured number.
By their numbers in this assay, from the lowest: compounds 2, 4 and 3 (each within the scatter of the next, the first and the last beyond it). At a limit, above all of these: compound 1.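

In this assay, methoxy in place of trifluoromethyl gives a 1.7-fold lower number from compound 3 to compound 4 (0.22 log units; within the scatter), and methoxy in place of methyl gives a 1.3-fold higher number from compound 2 to compound 4 (0.12 log units; within the scatter), so on this aromatic carbon, para to a large group, methoxy cannot be ordered against either of the other two groups, even though those two stood apart beyond the scatter. Among these compounds, replacing dimethylamino with methyl on an aromatic carbon elsewhere gives an at least 3.9-fold lower number from compound 1 to compound 4 (0.59 log units; beyond the scatter), the first step in these compounds to show that a second position also bears on the reading. That step has only a lower bound, since compound 1 reads as a limit and not a number: the limit of > 10000 nM in this assay, at which 1 of the 4 values shown sits.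

Going by these compounds, how an amine or a carboxylic acid on the para carbon would read remains open. So does the effect of a longer chain in place of the methyl of compound 4.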